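A few compounds are considered here, and "the series" means these few. Any claim that something is new, unique, unknown or untested is made for them only; others in the source may bear on it.

Compound 1 `Cc1cc(C(=O)NC(C)C)nn1Cc1cc(Cl)ccc1OCc1ccccc1` was tested in an assay on CHO-K1 cells for displacement of a labelled ligand from prostaglandin E2 receptor EP1 subtype (Homo sapiens) (a lower number here means a stronger inhibitor, a higher number a weaker inhibitor), where compound 1 gives 126 nM. Of the three compounds measured it stands second highest. Compound 2 `CC(=O)Nc1cc(C)n(Cc2cc(Cl)ccc2OCc2ccccc2)n1` gives 316 nM and compound 3 `Cc1cc(NC(=O)C2CCCO2)nn1Cc1cc(Cl)ccc1OCc1ccccc1` gives 39.8 nM. The step to compound 4 `Cc1cc(NC(=O)c2ccccc2)nn1Cc1cc(Cl)ccc1OCc1ccccc1` alters the group on the five-membered aromatic ring with 2 nitrogen: benzamido in place of isopropylcarbamoyl on an aromatic carbon. Among the compounds with values here, two measured steps bear on it, as each also exchanges that group for an amide. The change to acetamido gave a 2.5-fold higher number from compound 1 to compound 2 (0.40 log units; beyond the scatter), whereas the change to ((oxolan-2-yl)carbonyl)amino gave a 3.2-fold lower number from compound 1 to compound 3 (0.50 log units; beyond the scatter). Within those two amides, a 7.9-fold lower number from compound 2 to compound 3 (0.90 log units; beyond the scatter). Benzamido, like the group in compound 3 with its 39.8 nM, is an amide bearing a ring rather than a small chain. A modest lowering is therefore expected, a 2.5-fold lower number from compound 1 to compound 4 (0.40 log units; beyond the scatter). Compound 4 is estimated at 50 nM, within a range of 20 nM to 125 nM.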

Compound 4, half-maximal inhibitory concentration: 15.9 nM
For compound 4 the middle estimate is 3.1-fold (0.50 log units) above the measured one; measured number outside the range, below it.
By their numbers in this assay, from the lowest: compound 4; then compound 3; then compound 1; then compound 2.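

Benzamido gives the lowest number yet at this position, with a 7.9-fold lower number from compound 1 to compound 4 (0.90 log units; beyond the scatter), and the aromatic ring outdoes the ring of compound 3, with a 2.5-fold lower number from compound 3 to compound 4 (0.40 log units; beyond the scatter). With the amide kept, the group on the carbonyl carbon carries a large effect: phenyl in place of methyl gives a 20-fold lower number from compound 2 to compound 4 (1.30 log units; beyond the scatter). Nothing measured here explains why phenyl gives the lowest number. From the compounds shown here alone, whether the ring must be aromatic stays open, and cyclohexyl on the carbonyl carbon would test that. Also open, going by these compounds, is how a chlorine or methoxy group on the phenyl ring, or a pyridine ring in its place, would change the number.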